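Furan in place of fluorophenyl on the shared core

This account rests on a few compounds, and the source may have more. Where it says the series, first, only, none or still open, it means among the compounds named here.

Compound 1 `Nc1nc(-c2ccc(Cl)cc2)c(CC(=O)O)s1`: in an in vitro assay on HEK385-7 cells for displacement of a labelled ligand from prostaglandin D2 receptor 2 (Homo sapiens) (a higher number here means a weaker inhibitor, a lower number a stronger inhibitor), compound 1 gives > 100000 nM, a limit of the assay rather than a number.
Compound 2 `O=C(O)Cc1sc(C(c2ccccc2)c2ccccc2)nc1-c1ccc(F)c(F)c1`: compound 2 gives 4.1 nM.
Compound 3 `O=C(O)Cc1sc(C(c2ccc(F)cc2)c2ccc(F)cc2)nc1-c1cccc(F)c1`: compound 3 gives 1.4 nM.

Compound 3 has the lowest of the two numbers shown; compound 2 lies above it by more than the usual scatter, so compound 3 is the stronger inhibitor of the two.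

Compound 4 `O=C(O)Cc1sc(C(c2ccc(F)cc2)c2ccc(F)cc2)nc1-c1ccoc1` has not yet been measured. It differs from compound 3 by furan-3-yl in place of 3-fluorophenyl on an aromatic carbon. Within the data shown here, no measured pair shows what this change does here, so any expectation is tentative. The step of a 3.6-fold higher number from compound 3 to compound 4 (0.55 log units; beyond the scatter) is expected to be a modest weakening, possibly beyond the scatter. Compound 4 is estimated at 5 nM, with a range from 1.5 nM to 20 nM.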

Compound 4, half-maximal inhibitory concentration: 14 nM
The estimate for compound 4 lay 2.8-fold (0.45 log units) below the measured number; measured number inside the range.
By their numbers in this assay, from the lowest: compound 3; then compound 2; then compound 4. At a limit, above all of these: compound 1.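

In this assay, among these compounds, furan-3-yl in place of 3-fluorophenyl gives a 10-fold higher number from compound 3 to compound 4 (1.00 log units; beyond the scatter), the first reading of a change at this position alone, and it shows that the identity of this ring matters. The position still accepts the smaller, oxygen-bearing ring, as compound 4 remains a nanomolar inhibitor at 14 nM. No measurement shown bears on the reason for this step. From the compounds shown here alone, whether the loss follows from the ring size or from the ring oxygen stays open. A thiophene-3-yl or an unsubstituted phenyl at this position could help separate the two.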